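The source may hold more compounds than are shown below. What is called first, only, known or untested is meant among the compounds shown, and "the series" means these compounds.

Compound 1 `COc1ccc(Cc2coc3cccc(O)c3c2=O)cc1` is the shared core of this small series. In a functional assay on H9c2 cells (Mus musculus) for cytotoxicity against H9c2 (Rattus norvegicus), read by MTT assay, with a stated time of 24 h (on this read-out higher numbers stand for an effect only at larger amounts of compound and lower numbers for an effect already at smaller amounts), compound 1 gives > 100000 nM, which is a limit of the assay and not a number. Compound 2 `COc1ccc(Cc2coc3cc(OCCCCCl)cc(O)c3c2=O)cc1` carries 4-chlorobutoxy in place of hydrogen on an aromatic carbon. In this assay compound 2 gives > 100000 nM, again a limit rather than a measured number. The step that the two limits leave unreadable from compound 1 to compound 2 can therefore not be read in either size or direction, since both compounds rest on the same limit (the limit of > 100000 nM in this assay, at which 2 of the 2 values shown sit). Compound 3 `COc1ccc(Cc2coc3cc(OCC=C(C)C)cc(O)c3c2=O)cc1` differs from compound 2 by 2-methylprop-1-en-1-yl in place of 3-chloropropyl on a saturated chain carbon bound to an oxygen on an aromatic ring. Going by the values given here, no measured step bears on this exchange: the one step that exists between compounds is the unreadable one just described. With compound 2 standing only at the limit, the expectation is that compound 3 also stays at or near the limit in this assay. The step of a number no higher from compound 2 to compound 3 (the limit leaves the size open) is expected to be none beyond the scatter. The estimate for compound 3 is 100000 nM, with a range from 30000 nM to 300000 nM.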

Compound 3, half-maximal effective concentration: > 100000 nM
Compound 3: no number, only a limit (the forecaster's own chance of this, stated with the estimate: 85%); the middle value lies on the limit itself.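

No step among compound 1, compound 2 and compound 3 can be read, in size or in direction, since all three rest on one limit and not on a number: the limit of > 100000 nM in this assay, at which 3 of the 3 values shown sit.

The compounds shown leave open how 4-chlorobutoxy and (3-methylbut-2-en-1-yl)oxy compare with each other, or with hydrogen, in this assay.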